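Swapping a Heteroaromatic Ring Beside the Sulfoxide

The source may hold more compounds than are shown below. What is called first, only, known or untested is meant among the compounds shown, and "the series" means these compounds.

Compound 1 `Cc1noc(C[S+]([O-])C(c2ccccc2)c2ccccc2)n1` gives 56700 nM in an assay on HEK293 cells for inhibition of sodium-dependent dopamine transporter (Homo sapiens), read by scintillation counting, with stated times of 5 min and 1 min (on this read-out lower numbers stand for stronger inhibition and higher numbers for weaker inhibition), the highest of the two numbers recorded. Compound 2 `[O-][S+](Cc1nc(C(F)(F)F)no1)C(c1ccccc1)c1ccccc1` gives 43700 nM in this assay, and the step of a 1.3-fold lower number from compound 1 to compound 2 (0.11 log units; within the scatter) changes only a group on the ring. Going by the values given here, compound 3 `[O-][S+](Cc1csc(Br)c1)C(c1ccccc1)c1ccccc1` carries the change (5-bromothiophen-3-yl in place of 3-methyl-1,2,4-oxadiazol-5-yl on a saturated chain carbon bound to a sulfur), replacing the whole ring rather than a group on it, so the one measured step does not bear on it directly. Among the compounds with values here, with no step of that kind recorded, compound 3 is estimated near compound 1 at 40000 nM, within 8000 nM to 150000 nM, the expected step being a 1.4-fold lower number from compound 1 to compound 3 (0.15 log units; within the scatter).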

Compound 3, half-maximal inhibitory concentration: 16600 nM
Estimate against measurement, compound 3: 2.4-fold (0.38 log units) above; measured number inside the range.
By their numbers in this assay, from the lowest: compound 3; then compounds 2 and 1 (each within the scatter of the next).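

Replacing the whole ring on this saturated chain carbon moves the number further than the group change on the ring did: 5-bromothiophen-3-yl in place of 3-methyl-1,2,4-oxadiazol-5-yl gives a 3.4-fold lower number from compound 1 to compound 3 (0.53 log units; beyond the scatter). So in this assay this position responds to the identity of the ring, although the ring and the bromine change together in this single step. Nothing measured here explains the shift. Still open, from the compounds shown here alone, is how much of the step belongs to the bromine and how much to the thiophene, and how an amine or a carboxylic acid on the ring would read out.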